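Ethylamino on the shared core: expectation for compound 4

A few compounds are considered here, and "the series" means these few. Any claim that something is new, unique, unknown or untested is made for them only; others in the source may bear on it.

In a physicochemical assay for lipophilicity (a higher number here means a more lipophilic compound, a lower number a more polar compound), compound 1 `COc1nn(C)c2ncnc(NS(=O)(=O)c3cccc(Cl)c3Cl)c12` gives 2.4, the highest of the three numbers on hand, though its neighbours sit within the usual scatter of it. Compound 2 `COCCOc1nn(C)c2ncnc(NS(=O)(=O)c3cccc(Cl)c3Cl)c12` gives 2.3, and the step of a number 0.10 log units lower from compound 1 to compound 2 (within the scatter) is within the scatter. Compound 3 `COc1nn(C2COC2)c2ncnc(NS(=O)(=O)c3cccc(Cl)c3Cl)c12` gives 2.1, and the step of a number 0.30 log units lower from compound 1 to compound 3 (within the scatter) is likewise within the scatter. Neither change on the methoxy chain nor on the aromatic nitrogen therefore moves this assay beyond its noise.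

Compound 4 `CCNc1nc(NS(=O)(=O)c2cccc(Cl)c2Cl)c2c(OC)nn(C)c2n1` differs from compound 1 in one place: ethylamino in place of hydrogen on an aromatic carbon. Among the measured compounds shown here, none of the measured steps touches this position or this kind of group; the two steps that exist concern a chain oxygen and an aromatic nitrogen, and both are within the scatter, so they offer no direct precedent. The change adds three heavy atoms with one donor and one acceptor, and on such a core an entering ethylamino is generally expected to leave the distribution coefficient a little higher rather than lower. For compound 4 the expected step is a number 0.30 log units higher from compound 1 to compound 4 (within the scatter), modest and uncertain. Compound 4 is therefore estimated at 2.7, between 2.2 and 3.2, with the measurement still outstanding.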

Compound 4, distribution coefficient: 4.2
For compound 4 the middle estimate is 1.50 log units below the measured one; the whole stated range lies below it.
By their numbers in this assay, from the lowest: compounds 3, 2 and 1 (each within the scatter of the next); then compound 4.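

On the aromatic carbon between two ring nitrogen atoms, ethylamino in place of hydrogen gives in this assay a number 1.80 log units higher from compound 1 to compound 4 (beyond the scatter), and this is the only listed step in the series that lies beyond the scatter. Among the compounds shown here, the earlier steps, at the chain on the ring oxygen and at the aromatic nitrogen, stayed within the scatter, so this carbon is the first place on the shared core where a single change is seen to move the read-out clearly, and the move is large and upward. No measurement at hand bears on why a change of this size occurs at this position.

The compounds shown hold only hydrogen or ethylamino at this carbon, so they leave open whether the step belongs to ethylamino itself or would also appear with a plain amino group, a methyl group, a dimethylamino group or a longer chain such as propylamino. They also leave open whether the same step would hold on the core of compound 2 or compound 3, where the neighbouring changes differ from those in compound 1.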